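Swapping Fluoro for Chloro on a Potent Indole-Type Inhibitor

A few compounds are considered here, and "the series" means these few. Any claim that something is new, unique, unknown or untested is made for them only; others in the source may bear on it.

Of the compounds shown here, three have been measured in an assay on isolated protein for inhibition of Calpain-1 catalytic subunit (Sus scrofa); on this read-out lower numbers stand for stronger inhibition and higher numbers for weaker inhibition. Compound 1 `O=C(O)/C(S)=C/c1c[nH]c2cccc(F)c12` gives 300 nM and holds the lowest number of the three. Compound 2 `O=C(O)/C(S)=C/c1cccc(Cl)c1` gives 13100 nM, and compound 3 `O=C(O)/C(S)=C/c1ccccc1I` gives 42800 nM; both gaps from compound 1 lie well beyond the scatter, so compound 1 is the strongest inhibitor of the set on this read-out.

Compound 4 `O=C(O)/C(S)=C/c1c[nH]c2cccc(Cl)c12` has not yet been measured. Its difference from compound 1 is a single halogen exchange: chloro in place of fluoro on an aromatic carbon. Within the data shown here, no directly comparable step between two measured compounds exists for this exchange, so the expectation rests on the shared core and the small size of the change.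

Compound 4 is expected to remain close to compound 1, with a step of a 1.2-fold lower number from compound 1 to compound 4 (0.08 log units; within the scatter) that is estimated to fall within the scatter of repeated measurements, in either direction. The estimated value for compound 4 in this assay is 250 nM, expected to lie between 80 nM and 900 nM.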

Compound 4, half-maximal inhibitory concentration: 140 nM
The estimate for compound 4 lay 1.8-fold (0.25 log units) above the measured number; the range from low to high includes it.
By their numbers in this assay, from the lowest: compound 4; then compound 1; then compound 2; then compound 3.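

In this assay, placing chloro instead of fluoro on this aromatic carbon, ortho to a fused ring and meta to a fused ring, gives a 2.1-fold lower number from compound 1 to compound 4 (0.33 log units; beyond the scatter), a modest step. Among these compounds, the earlier compounds offered no single change on the shared core, so this is the first direct reading of this position: it takes chloro in place of fluoro with no loss of inhibition, and the number moves slightly lower. No measurement shown here accounts for the direction of this step.

The compounds shown leave open how bromo, a methoxy group or an amine on this same carbon would read. Going by these compounds, they also leave open how a plain hydrogen at this place would compare with fluoro and chloro, so the contribution of either halogen itself remains unknown.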